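The source may hold more compounds than are shown below. What is called first, only, known or untested is meant among the compounds shown, and "the series" means these compounds.

Compound 1 `C#CCSc1nc(Nc2ccc(OC)cc2)c(C#N)c(-c2ccccc2)n1` gives 35600 nM in a functional assay on MCF7 cells (Homo sapiens) for inhibition, read by MTT assay, with a stated time of 72 h; a higher number here means a weaker inhibitor, a lower number a stronger inhibitor.
Compound 2 `C#CCSc1nc(Nc2ccc(Cl)cc2)c(C#N)c(-c2ccccc2)n1` reaches only a limit of this assay, > 128000 nM, not a number.
Compound 3 `N#Cc1c(Nc2cccc(Cl)c2)nc(SCc2cn(Cc3ccccc3Cl)nn2)nc1-c1ccccc1` gives 12000 nM in this assay.

Of the two numbers in hand, compound 3 has the lowest, and so is the stronger inhibitor of the pair; compound 1 stands nearest, with a higher number that lies beyond the usual scatter. Compound 2 sits at a limit and cannot be ranked more finely.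

Compound 4 `N#Cc1c(Nc2ccc(F)cc2)nc(SCc2cn(Cc3ccccc3Cl)nn2)nc1-c1ccccc1` differs from compound 3 in one place: 4-fluorophenyl in place of 3-chlorophenyl on a nitrogen on an aromatic ring. Within the data shown here, the only measured step touches the same amino-linked ring but is a different exchange: an at least 3.5-fold higher number from compound 1 to compound 2 (0.55 log units; beyond the scatter). On these data alone, it ends at a limit (the limit of > 128000 nM in this assay, at which 1 of the 3 values shown sits), so its true size is unknown, and it tells little about swapping one halogen for another at a different place. Among the measured compounds shown here, no measured step pairs chloro against fluoro on this ring. The expectation is therefore cautious: a change of no more than a modest size, with the direction uncertain, leaning slightly toward a weaker inhibitor.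

Compound 4 is expected at about 20000 nM, with a range of 6000 nM to 70000 nM. The expected step of a 1.7-fold higher number from compound 3 to compound 4 (0.22 log units; within the scatter) is an estimate, not a measurement.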

Compound 4, half-maximal inhibitory concentration: 19900 nM
Compound 4: the middle estimate sits 1.0-fold (0.00 log units) above what was measured; low and high end bracket the measured number.
By their numbers in this assay, from the lowest: compounds 3, 4 and 1 (each within the scatter of the next, the first and the last beyond it). At a limit, above all of these: compound 2.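

The exchange of 3-chlorophenyl for 4-fluorophenyl on the amino nitrogen gives a 1.7-fold higher number from compound 3 to compound 4 (0.22 log units; within the scatter), so in this assay this position accepts a different halogen at a different place on the ring without a difference that stands clear of the scatter. Among these compounds, this is the first step on this ring with a real number at both ends, and it shows that a halogen-bearing ring here can be exchanged for another while the rest of the molecule stays the same. Compound 2 stands at a limit of the assay, and the earlier step on this ring therefore has no known size: the limit of > 128000 nM in this assay, at which 1 of the 4 values shown sits.

The exchange alters both the halogen and its place at once, so this one pair cannot separate the two, and a 3-fluorophenyl or a plain phenyl group at the same nitrogen, with the rest of compound 3 kept, would be needed to do so. On these data alone, it also remains open whether this tolerance extends beyond halogens, for instance to a ring carrying an amine or a carboxylic acid.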